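Methylpiperazine in place of ethylmethylamine: expected cytotoxicity

A few compounds are considered here, and "the series" means these few. Any claim that something is new, unique, unknown or untested is made for them only; others in the source may bear on it.

Of the compounds shown here, three have so far been tested in an ADME assay on MT4 cells (Homo sapiens) for cytotoxicity, read by MTT assay, with a stated time of 4 days; on this read-out higher numbers stand for lower toxicity in this test and lower numbers for higher toxicity in this test. Compound 1 `CCN(C)c1nc(Cc2c(F)cccc2F)cc(=O)[nH]1` reaches only a limit of the assay, > 89000 nM. Compound 2 `CC1CCCCN1c1nc(Cc2c(F)cccc2F)cc(=O)[nH]1` likewise reaches only a limit, > 78000 nM. Compound 3 `CCN(C)c1nc(Cc2c(F)cccc2F)c(C)c(=O)[nH]1` also reaches only a limit, > 85000 nM. Because (the limit of > 78000 nM in this assay, at which 1 of the 3 values shown sits), the limit of > 85000 nM in this assay, at which 1 of the 3 values shown sits, and the limit of > 89000 nM in this assay, at which 1 of the 3 values shown sits, are all limits, the step that the two limits leave unreadable from compound 1 to compound 2 and the step that the two limits leave unreadable from compound 1 to compound 3 cannot be given a size. Compound 3 therefore stands at a limit, as do the two other values, and no compound in the set has shown measurable toxicity.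

Compound 4 `Cc1c(Cc2c(F)cccc2F)nc(N2CCN(C)CC2)[nH]c1=O` differs from compound 3 by 4-methylpiperazin-1-yl in place of ethyl(methyl)amino on an aromatic carbon. Within the data shown here, no measured step addresses this change directly; the nearest comparison, the exchange of an open-chain amine for a ring amine in a step that the two limits leave unreadable from compound 1 to compound 2, is unreadable. The account expects compound 4 to stay at a limit in this assay, so the expected step that the limit leaves unreadable from compound 3 to compound 4 is none beyond the scatter. The estimate for compound 4 is 90000 nM, within a range from 40000 nM to 200000 nM.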

Compound 4, half-maximal cytotoxic concentration: > 75000 nM
Compound 4 was reported as a limit; the forecaster's own chance of this, stated with the estimate: 80%; the middle value lies beyond the limit too.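

In this assay compound 4 gives > 75000 nM, which is a limit of the assay. Compound 3 also stands at a limit, so the change between compound 3 and compound 4 cannot be given a size. The compounds shown leave open at what concentration, if any, compounds 1 to 4 would show toxicity in this assay.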